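Selenium series on human fibroblasts: notes before compound 3

The source may hold more compounds than are shown below. What is called first, only, known or untested is meant among the compounds shown, and "the series" means these compounds.

Measured so far:
compound 1 `CC(C)C(Nc1ccc([Se][Se]c2ccc(NC(c3nnnn3Cc3ccccc3)C(C)C)cc2)cc1)c1nnnn1Cc1ccccc1` — >= 100000 nM
compound 2 `CC1=C([Se]c2ccc(NCc3nnnn3C(C)(C)C)cc2)C(=O)c2ccccc2C1=O` — 48000 nM

In a toxicity assay on WI-38 cells (Homo sapiens) for cytotoxicity, read by MTT assay, with a stated time of 48 h (a higher number here means a weaker inhibitor, a lower number a stronger inhibitor), compound 1 gives >= 100000 nM, which is a limit of the assay and not a number. Within the data shown here, compound 2 gives 48000 nM in this assay and is the only compound with a number. Compound 3 `CC1=C([Se]c2ccc(NC(c3ccc(C)cc3)c3nnnn3C(C)(C)C)cc2)C(=O)c2ccccc2C1=O` differs from compound 2 by 4-methylphenyl in place of hydrogen on a saturated chain carbon bound to an aromatic carbon and a nitrogen on an aromatic ring. Among the measured compounds shown here, no measured pair shows a change of this kind, so the expected step in this assay is small, at most a modest move toward a lower number and possibly nothing beyond the scatter: the estimate for the step is a 1.6-fold lower number from compound 2 to compound 3 (0.20 log units; within the scatter). Compound 3 is expected at 30000 nM, within 8000 nM to 100000 nM.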

Compound 3, half-maximal inhibitory concentration: 36000 nM
The estimate for compound 3 lay 1.2-fold (0.08 log units) below the measured number; measured number inside the range.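

Among these compounds, on the saturated chain carbon bound to an aromatic carbon and a nitrogen on an aromatic ring, 4-methylphenyl in place of hydrogen gives in this assay a 1.3-fold lower number from compound 2 to compound 3 (0.12 log units; within the scatter), the only step read at this position. This carbon thus carries an added aromatic ring with no move beyond the scatter in this cell toxicity read-out. The span of readable numbers has a ceiling: the limit of >= 100000 nM in this assay, at which 1 of the 3 values shown sits.

Open, as far as these compounds go, is whether an amine, a carboxylic acid or a longer chain on this carbon would read the same way. A single group gives no trend at this position.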